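The compounds below may be only part of what the source reports. "The series", "measured", "known", "first", "only" and "open" are said of these compounds alone.

Measured compounds in the series:

Compound 1, `Cc1cc(OCC(=O)O)cc2ccn(Cc3ccc(O)c(C(C)C)c3)c12` — in an assay on HeLa cells for displacement of a labelled ligand from thyroid hormone receptor alpha (Homo sapiens) (a higher number here means a weaker inhibitor, a lower number a stronger inhibitor), compound 1 gives 1.09 nM
Compound 2, `CC(C)c1cc(Cn2ccc3cc(OCC(=O)O)cc(Cl)c32)ccc1O` — in this assay compound 2 gives 0.35 nM
Compound 3, `Cc1cn(Cc2ccc(O)c(C(C)C)c2)c2c(C)cc(OCC(=O)O)cc12` — in this assay compound 3 gives 2.77 nM

Compound 1 and compound 2 differ by chloro in place of methyl on an aromatic carbon. That change gave a 3.1-fold lower number from compound 1 to compound 2 (0.49 log units; beyond the scatter). Compound 3 carries a different core from compound 1, the difference being (methyl in place of hydrogen on an aromatic carbon), and that change gave a 2.5-fold higher number from compound 1 to compound 3 (0.41 log units; beyond the scatter). Compound 3 therefore stands highest of the three numbers.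

Compound 4, `Cc1cn(Cc2ccc(O)c(C(C)C)c2)c2c(Cl)cc(OCC(=O)O)cc12`, has not yet been measured. Within the data shown here, it differs from compound 3 by chloro in place of methyl on an aromatic carbon, which is the same change as the one from compound 1 to compound 2: the place description reads the same in both cases. There is one earlier instance of this change among the measured compounds, so the expectation rests on a single step.

Among the measured compounds shown here, for compound 4 the expected step in this assay is a 3.1-fold lower number from compound 3 to compound 4 (0.49 log units; beyond the scatter), which is taken to be close to the one measured step because a 3.1-fold lower number from compound 1 to compound 2 (0.49 log units; beyond the scatter) is the only measured instance of the change. Compound 4 is estimated at 0.9 nM, with a range from 0.4 nM to 2 nM.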

Compound 4, inhibition constant: 0.51 nM
Compound 4: middle estimate off by 1.8-fold (0.25 log units), on the high side, within the range that was stated.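

In this assay, chloro in place of methyl on an aromatic carbon gave a 5.4-fold lower number from compound 3 to compound 4 (0.73 log units; beyond the scatter), and the two instances of this change agree: the same change on two cores in this assay, a 3.1-fold lower number (0.49 log units; beyond the scatter) from compound 1 to compound 2 and a 5.4-fold lower number (0.73 log units; beyond the scatter) from compound 3 to compound 4, 1.7-fold (0.24 log units) apart, within the scatter of two such steps. Methyl in place of hydrogen on an aromatic carbon gave a 1.5-fold higher number from compound 2 to compound 4 (0.16 log units; within the scatter), a step within the scatter whose earlier counterpart lies beyond it, yet the two cannot be told apart: the same change on two cores in this assay, a 2.5-fold higher number (0.41 log units; beyond the scatter) from compound 1 to compound 3 and a 1.5-fold higher number (0.16 log units; within the scatter) from compound 2 to compound 4, 1.7-fold (0.24 log units) apart, within the scatter of two such steps. Both changes therefore carried over between the cores shown, but each rests on only two instances from one set of four compounds, so this shows neither that they would carry over to other cores nor why the steps take the sizes they do.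

Still open, from the compounds shown here alone, is whether a bromo or nitrile group on the same aromatic carbon would follow the chloro compounds. Also open, going by these compounds, is whether the steps would hold with a carboxamide in place of the carboxylic acid of the carboxymethoxy group, or in any assay other than this assay.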